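Aryl swap on the enone arm: compound 2 to compound 4

The source may report more compounds than this note shows. Statements on the series, on what has been measured and on what is new or still open speak of the compounds shown alone.

Measured compounds:
compound 1 `COc1ccc(/C=C/C(=O)c2ccc(OCCCSC(=S)N3CCN(C)CC3)cc2)cc1` gives 29500 nM
compound 2 `O=C(/C=C/c1cccnc1)c1ccc(OCCCSC(=S)N2CCCC2)cc1` gives 24500 nM
compound 3 `O=C(/C=C/c1cccs1)c1ccc(OCCCSC(=S)N2CCCCC2)cc1` gives 38200 nM

All three were tested in a functional assay on SK-N-SH cells (Homo sapiens) for inhibition, read by MTT assay, with a stated time of 72 h; on this read-out lower numbers stand for stronger inhibition and higher numbers for weaker inhibition. Compound 2 sits at the low end of the three numbers in this assay, yet compound 1 and compound 3 both lie within the usual scatter of it, so the three cannot be told apart on these data.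

Compound 4 `O=C(/C=C/c1ccc(Cl)cc1)c1ccc(OCCCSC(=S)N2CCCC2)cc1` has not been measured. It differs from compound 2 in one place: 4-chlorophenyl in place of pyridin-3-yl on a double-bonded chain carbon bound to a double-bonded chain carbon. Going by the values given here, no pair of measured compounds differs in just this way, so no measured step guides the expectation. Since the three measured compounds spread so little across different aryl groups, in this assay the expected step is a 1.1-fold lower number from compound 2 to compound 4 (0.05 log units; within the scatter), not beyond the scatter. Compound 4 is therefore estimated at 22000 nM, with a range from 10000 nM to 48000 nM.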

Compound 4, half-maximal inhibitory concentration: 19100 nM
The estimate for compound 4 lay 1.2-fold (0.06 log units) above the measured number, within the range that was stated.
By their numbers in this assay, from the lowest: compounds 4, 2, 1 and 3 (each within the scatter of the next).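

In this assay, 4-chlorophenyl in place of pyridin-3-yl on a double-bonded chain carbon bound to a double-bonded chain carbon gives a 1.3-fold lower number from compound 2 to compound 4 (0.11 log units; within the scatter). Going by these compounds alone, this is the first comparison that differs in one place, and at this position, exchanging the ring nitrogen and its hydrogen-bond acceptor for an all-carbon ring carrying chlorine produces no resolvable change. Nothing available bears on the reason for this result.

Going by these compounds, whether a carboxylic acid or an amine on this aromatic ring would move the number beyond the scatter remains open.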